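This account rests on a few compounds, and the source may have more. Where it says the series, first, only, none or still open, it means among the compounds named here.

Compound 1 `O=C(NC[C@H](NS(=O)(=O)c1ccccc1)C(=O)O)c1cc2cc(CCC3CCNCC3)sc2s1` and compound 3 `O=C(NC[C@H](NS(=O)(=O)c1ccccc1)C(=O)O)c1cc2sc(CCC3CCNCC3)cc2s1` are built from the same atoms joined differently; the difference between their two cores is not broken down here. In a functional assay for inhibition, with Homo sapiens as the target (on this read-out lower numbers stand for stronger inhibition and higher numbers for weaker inhibition), compound 1 gives 8 nM, and compound 3 gives 8 nM, the two numbers lying within the scatter of one another. Compound 2 `CCCCS(=O)(=O)N[C@@H](CNC(=O)c1cc2cc(CCC3CCNCC3)sc2s1)C(=O)O` is compound 1 with the change (butyl in place of phenyl on a sulfonyl sulfur), and in this assay compound 2 gives 32 nM; the measured step is a 4.0-fold higher number from compound 1 to compound 2 (0.60 log units; beyond the scatter). Compound 4 `CCCCS(=O)(=O)N[C@@H](CNC(=O)c1cc2sc(CCC3CCNCC3)cc2s1)C(=O)O` has not yet been measured. It stands to compound 3 exactly as compound 2 stands to compound 1: the change is butyl in place of phenyl on a sulfonyl sulfur, the same change at the same place, occurring twice among these four compounds. The step is expected to be about as large as the earlier one, an estimated 4.0-fold higher number from compound 3 to compound 4 (0.60 log units; beyond the scatter), because a 4.0-fold higher number from compound 1 to compound 2 (0.60 log units; beyond the scatter) was seen for this change while compound 3 starts level with compound 1. Compound 4 is therefore estimated at 32 nM in this assay. The range expected for compound 4 runs from 16 nM to 64 nM.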

Compound 4, half-maximal inhibitory concentration: 10 nM
For compound 4 the middle estimate is 3.2-fold (0.51 log units) above the measured one, outside the stated range (below it).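

In this assay, for the compounds shown here, butyl in place of phenyl on a sulfonyl sulfur gives a 1.3-fold higher number from compound 3 to compound 4 (0.10 log units; within the scatter) and so leaves no step that stands out from the scatter on this second core. The size of the step therefore depends on which of these two cores carries the change, and the earlier step cannot simply be transferred from one to the other: the same change on two cores in this assay, a 4.0-fold higher number (0.60 log units; beyond the scatter) from compound 1 to compound 2 and a 1.3-fold higher number (0.10 log units; within the scatter) from compound 3 to compound 4, 3.2-fold (0.51 log units) apart, beyond the scatter of two such steps. This does not show why the two cores part ways, and two pairs give no rule for how the same change would behave on any further core.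

The compounds shown leave open whether a shorter or longer chain on the sulfonyl sulfur, or a phenyl ring bearing a fluorine or a methoxy group, would show the same split between the two cores. They also leave open whether the split would persist if an ester or an amide replaced the carboxylic acid.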